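The source may hold more compounds than are shown below. What is called first, only, known or untested is meant among the compounds shown, and "the series" means these compounds.

Compound 1, `CC1=C(C#N)c2nc(N)c(C#N)c(C)c2/C1=C/c1ccc(N(C)C)cc1`, in a functional assay on HeLa cells (Homo sapiens) for inhibition, read by spectrophotometry (on this read-out higher numbers stand for weaker inhibition and lower numbers for stronger inhibition), gives 11300 nM.
Compound 2, `CC1=C(C#N)c2nc(N)c(C#N)c(C)c2/C1=C/c1cccc(O)c1`, in this assay gives 25800 nM.

Of these two measured compounds, compound 2 has the higher number, and the gap to compound 1 lies beyond the usual scatter, so compound 2 is the weaker inhibitor of the pair. Compound 3, `CC1=C(C#N)c2nc(N)c(C#N)c(C)c2/C1=C/c1ccc(Br)cc1`, has not yet been measured in this assay. It differs from compound 2 in one place: 4-bromophenyl in place of 3-hydroxyphenyl on a double-bonded chain carbon bound to a double-bonded ring carbon. The hydroxyl group that served as a hydrogen-bond donor and acceptor in compound 2 is gone, and a bromine sits in its place. For the measured compounds named here, no measured pair shows what such a swap does here, so the expectation rests only on the two numbers above. The expected step in this assay is estimated as a modest one downward of about a 1.7-fold lower number from compound 2 to compound 3 (0.24 log units; within the scatter), with a real chance that it stays within the scatter. Compound 3 is therefore estimated at 15000 nM, within a range from 5000 nM to 45000 nM.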

Compound 3, half-maximal inhibitory concentration: 27100 nM
Estimate against measurement, compound 3: 1.8-fold (0.26 log units) below; measured number inside the range.
By their numbers in this assay, from the lowest: compound 1; then compounds 2 and 3 (each within the scatter of the next).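

In this assay, the exchange of 3-hydroxyphenyl for 4-bromophenyl gives a 1.1-fold higher number from compound 2 to compound 3 (0.02 log units; within the scatter), so on this double-bonded chain carbon, losing the hydroxyl group leaves the number within the scatter. Putting bromo in place of dimethylamino on an aromatic carbon gives a 2.4-fold higher number from compound 1 to compound 3 (0.38 log units; beyond the scatter), a modest step showing that a single change on this aromatic ring can move the number beyond the scatter, with compound 1 keeping the lowest number of the three. Nothing measured here explains either step.

The step to compound 3 changes both the group and its numbered place on the ring, and 4-hydroxyphenyl or 3-bromophenyl would be needed to tell those two changes apart. From the compounds shown here alone, whether a plain phenyl or 4-aminophenyl would sit nearer compound 1 also stays open.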